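A few compounds are considered here, and "the series" means these few. Any claim that something is new, unique, unknown or untested is made for them only; others in the source may bear on it.

Measured so far:
compound 1 `CC(C)S(=O)(=O)N(C)c1ccc(N(C)S(=O)(=O)c2ccc(F)cc2)cc1` gives 0.01 mg/kg in a functional assay on the whole organism with Mus musculus as the target, with a stated time of 20 min; on this read-out lower numbers stand for an effect already at smaller amounts and higher numbers for an effect only at larger amounts of compound
compound 2 `CC(C)S(=O)(=O)Nc1ccc(N(C)S(=O)(=O)c2ccc(F)cc2)cc1` gives 0.1 mg/kg in this assay

Compound 2 stands at the higher of the two numbers, set apart from compound 1 by a 10-fold higher number from compound 1 to compound 2 (1.00 log units; beyond the scatter). Compound 3 `CC(C)S(=O)(=O)Nc1ccc(NS(=O)(=O)c2ccc(F)cc2)cc1` differs from compound 2 by hydrogen in place of methyl on a sulfonamide nitrogen. Within the data shown here, the one measured step, a 10-fold higher number from compound 1 to compound 2 (1.00 log units; beyond the scatter), was the same kind of change, hydrogen in place of methyl on a sulfonamide nitrogen, and it moved the number up modestly. A rise in the same direction is expected here, with an estimated step of a 5.0-fold higher number from compound 2 to compound 3 (0.70 log units; beyond the scatter) in this assay. Compound 3 is expected to give 0.5 mg/kg in this assay, within a range of 0.1 mg/kg to 3 mg/kg.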

Compound 3, minimum effective dose: 1 mg/kg
For compound 3 the middle estimate is 2.0-fold (0.30 log units) below the measured one; low and high end bracket the measured number.
By their numbers in this assay, from the lowest: compound 1; then compound 2; then compound 3.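

Removing the methyl from this second sulfonamide nitrogen also raises the number in this assay (a 10-fold higher number from compound 2 to compound 3 (1.00 log units; beyond the scatter)). The same change at the other sulfonamide nitrogen (a 10-fold higher number from compound 1 to compound 2 (1.00 log units; beyond the scatter)) moved it in the same direction, so the rise is not confined to one of the two nitrogens. Nothing measured here explains this rise.

Still open, on these data alone, is how this nitrogen behaves when the other sulfonamide nitrogen keeps its methyl. Also open, as far as these compounds go, is whether an ethyl group or a longer chain on either nitrogen would serve as well as methyl.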